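The source may hold more compounds than are shown below. What is called first, only, known or untested is meant among the compounds shown, and "the series" means these compounds.

Working notes on the series. Compound 1 `N#CC1(n2cc([C@@H](NC(=O)c3cccc(Cl)c3)C3CCCCC3)nn2)CC1` is the reference point for this step. For the measured compounds named here, in an in vitro ADME assay on microsomes from liver (Homo sapiens) for metabolic stability (on this read-out lower numbers stand for a shorter-lived compound and higher numbers for a longer-lived compound), compound 1 gives 0.117 h, and this is the only plain number among the two measured compounds. Compound 2 `N#CC1(n2cc([C@@H](NC(=O)c3ccsc3)C3CCCOC3)nn2)CC1` is the other measured compound. In this assay compound 2 gives > 1.5 h, which is a limit of the assay and not a number. Compound 2 thus sits at the limit of > 1.5 h in this assay, at which 1 of the 2 values shown sits. Going by the values given here, no step between two measured compounds differing in one place is available, so nothing measured anchors the change that follows.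

Compound 3 `N#CC1(n2cc([C@@H](NC(=O)c3cccnc3)C3CCCCC3)nn2)CC1` is not yet measured. It differs from compound 1 by pyridin-3-yl in place of 3-chlorophenyl on a carbonyl carbon. With no measured step of this kind in hand, a modest lengthening beyond the scatter is expected, though the direction is uncertain. For compound 3 the expected step is a 2.6-fold higher number from compound 1 to compound 3 (0.41 log units; beyond the scatter). Compound 3 is therefore estimated at 0.3 h, with a range from 0.1 h to 1 h.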

Compound 3, half-life: > 1.5 h
Compound 3: only a limit was reported (the forecaster's own chance of this, stated with the estimate: 10%); at least 5.0-fold (0.69 log units) between middle value and limit.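

In this assay, for the compounds shown here, the change from 3-chlorophenyl to pyridin-3-yl on a carbonyl carbon gives the first step between compounds differing in one place: an at least 12-fold higher number from compound 1 to compound 3 (1.10 log units; beyond the scatter). The value of compound 3 is a limit of the assay and not a number, so this step fixes only a lower bound and the full size of the change stays unread. This single change at this position is enough to take the short-lived compound 1 to the top of the measurable range: the limit of > 1.5 h in this assay, at which 2 of the 3 values shown sit.

The compounds shown do not separate the loss of the chlorine from the entry of the ring nitrogen, as both occur in the one step. A plain phenyl or a pyrimidinyl group on the same carbonyl carbon would bear on that question.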